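This account rests on a few compounds, and the source may have more. Where it says the series, first, only, none or still open, it means among the compounds named here.

Working notes on the series

Compound 1 `COc1ccc2c(c1)OC(c1cc(OC)c(OC)c(OC)c1)C(C(=O)NC(C)(C)C)=C2` gives 28400 nM in a functional assay for inhibition of nuclear factor NF-kappa-B complex (Homo sapiens); on this read-out higher numbers stand for weaker inhibition and lower numbers for stronger inhibition. Compound 2 `COc1ccc2c(c1)OC(c1cc(OC)c(OC)c(OC)c1)C(C(=O)OC(C)C)=C2` gives 11800 nM in this assay, and compound 3 `COc1ccc2c(c1)OC(c1cc(OC)c(OC)c(OC)c1)C(C(=O)Nc1ccccc1)=C2` gives 17500 nM. Compound 3 thus stands second highest of the three; its gaps to compound 2 and to compound 1 both lie within the scatter, so no order among the three can be claimed from these two pairs. For the measured compounds named here, the only step beyond the scatter is a 2.4-fold lower number from compound 1 to compound 2 (0.38 log units; beyond the scatter); the steps of a 1.6-fold lower number from compound 1 to compound 3 (0.21 log units; within the scatter) and a 1.5-fold higher number from compound 2 to compound 3 (0.17 log units; within the scatter) stay within it.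

Compound 4 `CCOCC1=Cc2ccc(OC)cc2OC1c1cc(OC)c(OC)c(OC)c1` is not yet measured. The change is ethoxymethyl in place of phenylcarbamoyl on a double-bonded ring carbon. Going by the values given here, none of the measured steps removes the carbonyl group; all three only exchange the group attached to it, and the whole spread across them is small. The closest bearing is therefore the modest step from compound 1 to compound 2 and the two steps within the scatter, which together give no direction for a change of this kind. For compound 4 the expectation is a step of a 1.1-fold higher number from compound 3 to compound 4 (0.06 log units; within the scatter), not clearly beyond the scatter. Compound 4 is accordingly estimated at 20000 nM, with a range from 6000 nM to 60000 nM.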

Compound 4, half-maximal inhibitory concentration: 21300 nM
Beside the measured number, compound 4's estimate is 1.1-fold (0.03 log units) below it; measured number inside the range.
By their numbers in this assay, from the lowest: compounds 2, 3, 4 and 1 (each within the scatter of the next, the first and the last beyond it).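

In this assay the position on the double-bonded ring carbon tolerates loss of the carbonyl: phenylcarbamoyl gives way to ethoxymethyl, which removes the aromatic ring and the hydrogen-bond donor, yet the result is a 1.2-fold higher number from compound 3 to compound 4 (0.09 log units; within the scatter) and no shift beyond the scatter. The same holds against the other two carbonyl groups, with a 1.8-fold higher number from compound 2 to compound 4 (0.26 log units; within the scatter) for isopropoxycarbonyl and a 1.3-fold lower number from compound 1 to compound 4 (0.12 log units; within the scatter) for (tert-butyl)carbamoyl, so among these four compounds a carbonyl at this position is not needed to keep the number in this range. No supporting data bear on why this exchange is so well tolerated.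

On these data alone, whether an aminomethyl group or a carboxylic acid on this ring carbon would move the number beyond the scatter remains open. So does the outcome for a longer alkoxyalkyl chain than ethoxymethyl.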